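A few compounds are considered here, and "the series" means these few. Any claim that something is new, unique, unknown or untested is made for them only; others in the source may bear on it.

Measured in an in vitro ADME assay on microsomes from liver (Mus musculus) for pharmacokinetics, read by LC-MS, with a stated time of 10 min, tested at 1 uM; a lower number here means slower removal, a higher number faster removal of the compound:
compound 1 `CC(C)c1ccc(NC(=O)[C@H]2CN(C)C[C@@H]2c2ccc(/C=C/C(=O)Nc3ccccc3N)cc2)cc1` gives 54 mL/min/kg
compound 2 `CN1C[C@H](C(=O)Nc2cccc(Cl)c2)[C@@H](c2ccc(/C=C/C(=O)Nc3ccccc3N)cc2)C1` gives 58 mL/min/kg
compound 3 `CN1C[C@H](C(=O)Nc2ccccc2F)[C@@H](c2ccc(/C=C/C(=O)Nc3ccccc3N)cc2)C1` gives 67 mL/min/kg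

Compound 3 sits within the scatter of both others: the steps of a 1.2-fold higher number from compound 1 to compound 3 (0.09 log units; within the scatter) and a 1.2-fold higher number from compound 2 to compound 3 (0.06 log units; within the scatter) are too small to count as real differences. Compound 4 `CN1C[C@H](C(=O)Nc2ccc(Cl)cn2)[C@@H](c2ccc(/C=C/C(=O)Nc3ccccc3N)cc2)C1` is not yet measured. It differs from compound 3 in one place: 5-chloropyridin-2-yl in place of 2-fluorophenyl on an amide-type nitrogen. Every step seen so far changes the group on the amide-type nitrogen, and none moved the number beyond the scatter: a 1.1-fold higher number from compound 1 to compound 2 (0.03 log units; within the scatter), a 1.2-fold higher number from compound 1 to compound 3 (0.09 log units; within the scatter), a 1.2-fold higher number from compound 2 to compound 3 (0.06 log units; within the scatter). So in this assay no step beyond the scatter is expected here either, a 1.1-fold lower number from compound 3 to compound 4 (0.05 log units; within the scatter). Compound 4 is therefore estimated at 60 mL/min/kg, with a range from 35 mL/min/kg to 105 mL/min/kg.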

Compound 4, clearance: 31 mL/min/kg
For compound 4 the middle estimate is 1.9-fold (0.29 log units) above the measured one, and the stated range ends above it.
By their numbers in this assay, from the lowest: compounds 4, 1, 2 and 3 (each within the scatter of the next, the first and the last beyond it).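

In this assay, among these compounds, this amide-type nitrogen gives the first step beyond the scatter: 5-chloropyridin-2-yl in place of 2-fluorophenyl gives a 2.2-fold lower number from compound 3 to compound 4 (0.33 log units; beyond the scatter). The same group in place of 3-chlorophenyl gives a 1.9-fold lower number from compound 2 to compound 4 (0.27 log units; within the scatter) and in place of 4-isopropylphenyl gives a 1.7-fold lower number from compound 1 to compound 4 (0.24 log units; within the scatter), so the change stands out against only one of the three earlier groups. Nothing measured here explains the step. On these data alone, the change swaps fluorine for chlorine and adds a ring nitrogen at once, so which of these matters stays open. Pyridin-2-yl without chlorine, or 4-chlorophenyl, on this nitrogen would separate the two.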